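This account rests on a few compounds, and the source may have more. Where it says the series, first, only, none or still open, it means among the compounds named here.

Measured so far:
compound 1, `Cc1[nH]c2ccc(Cl)cc2c(=O)c1Br`: 5000 nM
compound 2, `CCCCCCCc1c(C)[nH]c2cc(OC)c(Cl)cc2c1=O`: < 2000 nM
compound 3, `CCCCCCCCCc1c(C)[nH]c2cc(OC)c(Cl)cc2c1=O`: < 2000 nM

The read-out throughout is a physicochemical assay for solubility, read by HPLC, at pH 7.4; on this read-out lower numbers stand for lower solubility and higher numbers for higher solubility. Going by the values given here, compound 1 is the one compound of the three with a numbered value, giving 5000 nM. For compound 2 the read-out is a limit of the assay, not a number: < 2000 nM. For compound 3 the read-out is likewise a limit, < 2000 nM. Among the compounds with values here, the one step within the set, a step that the two limits leave unreadable from compound 2 to compound 3, cannot be sized. From the compounds shown here alone, its direction is unknown as well. Compound 2 therefore stands at the limit, and the limit of < 2000 nM in this assay, at which 2 of the 3 values shown sit, is all the set says about where the chain-bearing compounds of this core sit.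

The unmeasured compound 4, `CCCCC#Cc1c(C)[nH]c2cc(OC)c(Cl)cc2c1=O`, differs from compound 2 by hex-1-yn-1-yl in place of heptyl on an aromatic carbon. Within the data shown here, no measured step in this assay bears on such a change: the only step available is unreadable, and compound 1 carries no chain at all. The expectation rests only on compound 2 sitting at the limit < 2000 nM, so compound 4 is expected to sit close to the same limit, with a fair chance that the assay again reports only a limit. The expected step of an at least 1.2-fold higher number from compound 2 to compound 4 (0.09 log units; that floor lies within the scatter) is taken as lying within the scatter. Compound 4 is estimated at 2500 nM, in the range 700 nM to 9000 nM.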

Compound 4, solubility: > 20000 nM
Compound 4 ended at the assay's limit; the forecaster's own chance of this, stated with the estimate: 55%; middle value at least 8.0-fold (0.90 log units) away from the limit.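

Going by these compounds alone, on the aromatic carbon that carries the chain, replacing heptyl with hex-1-yn-1-yl gives the first readable step in this assay: an at least 10-fold higher number from compound 2 to compound 4 (1.00 log units; beyond the scatter). Within the data shown here, the earlier compounds showed nothing of this kind, since their only step joins two values at the same limit and leaves both size and direction unknown. Compound 4 gives > 20000 nM, which is a limit of the assay and not a number, and the series now has values at limits on both sides: the limit of > 20000 nM in this assay, at which 1 of the 4 values shown sits.

From the compounds shown here alone, the step from compound 2 to compound 3 cannot be read, so nothing is known about how saturated chain length acts on this read-out, and the exact size of the new step remains unknown. Going by these compounds, the change also alters two things at once, the triple bond and the chain length, so it remains open which of them goes with the higher number; a hexyl chain or a hept-1-yn-1-yl chain at the same aromatic carbon would separate the two.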